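From compound 2 to compound 4: a change on the nitrogen

A few compounds are considered here, and "the series" means these few. Any claim that something is new, unique, unknown or untested is made for them only; others in the source may bear on it.

Going by the values given here, in a functional assay on HCT-116 cells (Homo sapiens) for antiproliferative activity, read by MTT assay, with a stated time of 72 h (a higher number here means a weaker inhibitor, a lower number a stronger inhibitor), compound 2 `COc1ccc(/C=C2\S/C(=N\c3ccc(C)c(Cl)c3)N(C)C2=O)cc1` gives 14100 nM as one of only two numbers. Compound 1 `COc1ccc(/C=C2/CN(C)/C(=N/c3ccc(C(C)(C)C)cc3)S2)cc1` gives 25900 nM in this assay and lies within the scatter of compound 2, so no order is read between the two. Compound 3 `C=CC/N=C1/NCC(=C)S1` gives > 100000 nM in this assay and that value is a limit of the assay, not a number.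

Compound 4 `COc1ccc(/C=C2\S/C(=N\c3ccc(F)cc3)N(C)C2=O)cc1` has not yet been measured. Its change from compound 2 is 4-fluorophenyl in place of 3-chloro-4-methylphenyl on a double-bonded nitrogen and amounts to 4-fluorophenyl in place of 3-chloro-4-methylphenyl on a double-bonded nitrogen.

Among the compounds with values here, no two measured compounds differ in one place only, so the series offers no measured step against which to scale this change. A step beyond the scatter is not expected, and the expectation starts from compound 2 at 14100 nM as the reference value, with a slight lean toward a higher number. The expected change is a 1.4-fold higher number from compound 2 to compound 4 (0.15 log units; within the scatter) and it stays within the scatter. Compound 4 is expected at 20000 nM in this assay, with an estimated range of 7000 nM to 60000 nM for the eventual reading.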

Compound 4, half-maximal inhibitory concentration: 13300 nM
Beside the measured number, compound 4's estimate is 1.5-fold (0.18 log units) above it; the range from low to high includes it.
By their numbers in this assay, from the lowest: compounds 4, 2 and 1 (each within the scatter of the next). At a limit, above all of these: compound 3.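

Going by these compounds alone, this is the first step between two measured compounds that differ in one place only: in this assay, 4-fluorophenyl in place of 3-chloro-4-methylphenyl on a double-bonded nitrogen gives a 1.1-fold lower number from compound 2 to compound 4 (0.03 log units; within the scatter). At this position, then, the read-out does not tell the two substituted phenyl groups apart, and the shared core with its methoxyphenyl part carries either group with no step beyond the scatter. Compound 3 adds nothing to this comparison, as it differs in more than one place and its value is a limit of the assay, not a number: the limit of > 100000 nM in this assay, at which 1 of the 4 values shown sits.

Within the data shown here, the single step exchanges the chlorine, the methyl and the fluorine at once, so what each of them contributes on its own stays unresolved, and a phenyl group carrying only one of them would be needed to separate them. Also open, on these data alone, is whether any group on this nitrogen moves the number beyond the scatter, for example a phenyl group bearing an amine or a carboxylic acid, or a longer alkyl chain in place of the phenyl ring.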